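This account rests on a few compounds, and the source may have more. Where it says the series, first, only, none or still open, it means among the compounds named here.

Of the compounds shown here, two have been measured in an ADME assay on HEK293 cells (Homo sapiens) for cytotoxicity, read by sulforhodamine B assay, with a stated time of 48 h, tested at 10 uM; on this read-out lower numbers stand for less inhibition and higher numbers for more inhibition at the one concentration tested (going by the name of the read-out): compound 1 `COc1nc2ccc(Br)cc2cc1C(c1ccccc1)n1cc(-c2ccc(Br)cc2)nn1` and compound 2 `COc1nc2ccc(Br)cc2cc1C(c1ccccc1)n1cc(-c2ccc(OC(F)(F)F)cc2)nn1`. Compound 1 gives 6.28%, which is the highest of the two numbers, and compound 2 gives 5.8%; the step of a number 0.5 percentage points lower from compound 1 to compound 2 (within the scatter) lies within the usual scatter, so the two numbers cannot be told apart.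

Compound 3 `COc1nc2ccc(Br)cc2cc1C(c1ccccc1)n1cc(-c2ccccc2)nn1` has not yet been measured. Compared with compound 1, its change is hydrogen in place of bromo on an aromatic carbon. Going by the values given here, the only measured step that bears on this change is the one from compound 1 to compound 2, in which the same bromo was replaced by trifluoromethoxy; that step was a number 0.5 percentage points lower from compound 1 to compound 2 (within the scatter), within the scatter. Replacing the bromo with hydrogen is therefore expected to give no step beyond the scatter, and the expected step of a number 0.3 percentage points lower from compound 1 to compound 3 (within the scatter) reflects this. Compound 3 is estimated at 6%, in a range from -4% to 16%.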

Compound 3, a percentage reported as inhibition, at one concentration (the size of the read-out at that concentration, not a potency): 8.25%
The estimate for compound 3 lay 2.3 percentage points below the measured number; the measured number falls inside the stated range.
By their numbers in this assay, from the lowest: compounds 2, 1 and 3 (each within the scatter of the next).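

Compound 3 shows this position with only hydrogen on it, and in this assay the change from 4-bromophenyl to phenyl gives a number 2 percentage points higher from compound 1 to compound 3 (within the scatter). Hydrogen in place of trifluoromethoxy gives a number 2.5 percentage points higher from compound 2 to compound 3 (within the scatter), so the readings with bromo, trifluoromethoxy and hydrogen at this position cannot be told apart, even though hydrogen brings no heavy atom at all. No further measurement is available that could explain these numbers.

The compounds shown leave open whether an amine or a carboxylic acid at this position would move the number beyond the usual scatter. They also leave open whether a change elsewhere on the shared core, such as replacing its methoxy group with a longer chain, would do so.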